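A few compounds are considered here, and "the series" means these few. Any claim that something is new, unique, unknown or untested is made for them only; others in the source may bear on it.

Measured compounds in the series:

Compound 1, `CO[C@@H]1[C@@H](O)[C@@H](O)[C@H]2O[C@]1(C)n1c3ccccc3c3c4c(c5c6ccccc6n2c5c31)C(=O)NC4`; in an assay on isolated protein for inhibition of protein kinase C theta type (Homo sapiens), read by HTRF (a lower number here means a stronger inhibitor, a higher number a weaker inhibitor), compound 1 gives 1010 nM.
Compound 2, `CO[C@@H]1[C@@H](O)[C@@H](O)[C@H]2O[C@]1(C)n1c3ccccc3c3c4c(c5c6ccccc6n2c5c31)C(=O)N[C@@H]4O`; in this assay compound 2 gives only the assay limit > 2500 nM.

Compound 2 thus stands at the weak end of the two, fixed only as a limit and not as a number, since (the limit of > 2500 nM in this assay, at which 1 of the 2 values shown sits). For the measured compounds named here, the one measured step, an at least 2.4-fold higher number from compound 1 to compound 2 (0.39 log units; beyond the scatter), sets the distance between the two compounds.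

Compound 3, `CO[C@H]1NC(=O)c2c1c1c3ccccc3n3c1c1c2c2ccccc2n1[C@@H]1O[C@@]3(C)[C@H](OC)[C@@H](O)[C@H]1O`, differs from compound 2 by methyl in place of hydrogen on an oxygen on a saturated carbon. Going by the values given here, no measured step concerns methylation of that oxygen; the only step available, from compound 1 to compound 2, touches the same ring carbon but changes a different group, so it gives no direction for the present change. Compound 3 is therefore expected to stay near compound 2, with an estimated step that the limit leaves unreadable from compound 2 to compound 3 in this assay. The estimate for compound 3 is 4000 nM, in a range from 1500 nM to 15000 nM, most likely again reported as a limit.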

Compound 3, half-maximal inhibitory concentration: 890 nM
For compound 3 the middle estimate is 4.5-fold (0.65 log units) above the measured one, outside the stated range (below it).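

At this saturated ring carbon, the effect in this assay depends on the oxygen substituent and not merely on its presence: going from hydroxy to methoxy gives an at least 2.8-fold lower number from compound 2 to compound 3 (0.44 log units; beyond the scatter), so the weakening seen with hydroxy does not carry over to methoxy. Methoxy in place of hydrogen gives a 1.1-fold lower number from compound 1 to compound 3 (0.05 log units; within the scatter), which leaves compound 1 and compound 3 indistinguishable and shows that this carbon can carry methoxy with no readable change. Compound 2 is fixed only by a limit, so the hydroxy to methoxy step has a lower bound and no exact size: the limit of > 2500 nM in this assay, at which 1 of the 3 values shown sits.

From the compounds shown here alone, whether this carbon also accommodates a longer chain such as ethoxy, or an amine, remains open. For the compounds shown here, with only these three compounds, methoxy is the sole evidence that substitution here can be tolerated.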